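The source may hold more compounds than are shown below. What is called first, only, known or untested is meant among the compounds shown, and "the series" means these compounds.

Working notes on the series. Two compounds have been run so far in a functional assay on isolated protein for antagonist activity at adenosine receptor A2b (Homo sapiens) (on this read-out higher numbers stand for weaker inhibition and lower numbers for stronger inhibition), and both end at the assay floor. Compound 1, `CC(=O)Oc1ccc2cc(-c3cccs3)c(=O)oc2c1OC(C)=O`, gives in this assay only a limit, > 30000 nM, not a number. Compound 2, `CC(=O)Oc1cccc2cc(-c3cc(Br)cs3)c(=O)oc12`, likewise gives in this assay only a limit, > 30000 nM, not a number. Where compound 2 stands is therefore set by the limit of > 30000 nM in this assay, at which 2 of the 2 values shown sit: no measured value in the set sits anywhere else, so there is nothing to order it against.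

The next compound, compound 3, `CC(=O)Oc1ccc2cc(-c3cc(Br)cs3)c(=O)oc2c1OC(C)=O`, carries the acetoxy group of compound 2 and adds a second one: acetoxy in place of hydrogen on an aromatic carbon. Compound 1 already carries the same pair of acetoxy groups on the shared core with an unsubstituted thiophene and sits at the limit, so the change offers no measured foothold. Within the data shown here, no step between measured compounds exists in this assay; the expectation for compound 3 is no measurable step, a result again at the limit, with the estimated change from compound 2 to compound 3 being a step that the limit leaves unreadable from compound 2 to compound 3. The estimate for compound 3 in this assay is 50000 nM, expected to lie between 20000 nM and 200000 nM.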

Compound 3, inhibition constant: > 30000 nM
Compound 3 was reported as a limit; the forecaster's own chance of this, stated with the estimate: 80%; the middle value does not contradict the limit.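

In this assay compound 3 gives > 30000 nM, again a limit and not a number. No step can be read from compound 2 to compound 3 or from compound 1 to compound 3, because all three results end at the same limit: the limit of > 30000 nM in this assay, at which 3 of the 3 values shown sit. The compounds shown leave open whether acetoxy or bromo in place of hydrogen changes inhibition at all.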